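The source may report more compounds than this note shows. Statements on the series, on what has been measured and on what is new or still open speak of the compounds shown alone.

Measured so far:

Compound 1 `CCN(CC)S(=O)(=O)c1ccc(S(=O)(=O)N2CCC[C@@H](C(=O)NC3CN(C(=O)C4CC4)C3)C2)cc1` gives 2800 nM in a functional assay on MIA PaCa-2 cells (Homo sapiens) for inhibition, read by MTT assay, with a stated time of 7 days; a higher number here means a weaker inhibitor, a lower number a stronger inhibitor.
Compound 2 `CCOC(=O)[C@@H]1C[C@H](O)CN(S(=O)(=O)c2ccc(S(=O)(=O)N(CC)CC)cc2)C1` gives 1300 nM in this assay.
Compound 3 `CC(C)c1noc(N2CCN(C(=O)[C@@H]3CCCN(S(=O)(=O)c4ccc(S(=O)(=O)C5CCC5)cc4)C3)CC2)n1` gives 70 nM in this assay.

Of the three numbers, compound 1 has the highest. Compound 2 sits lower, by a gap beyond the usual scatter, and compound 3 sits far lower still, also well beyond the scatter; compound 1 is thus the weakest inhibitor of the set as it stands. Going by the values given here, no two of the measured compounds differ in only one place, so no single step has been measured.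

Compound 4 `CCN(CC)S(=O)(=O)c1ccc(S(=O)(=O)N2CCC[C@@H](C(=O)NC3CN(C(=O)NC(C)(C)C)C3)C2)cc1` departs from compound 1 at the carbonyl attached to the azetidine nitrogen: (tert-butyl)amino in place of cyclopropyl on a carbonyl carbon. The rest of the molecule, including the shared core and the bis-sulfonyl aryl piece, is unchanged. Among the compounds with values here, there is no measured step of this kind to lean on, so the expectation rests on the small size of the change at a peripheral position. The expected step from compound 1 to compound 4 in this assay is a 1.1-fold lower number from compound 1 to compound 4 (0.05 log units; within the scatter), that is, none beyond the scatter. Compound 4 is therefore estimated at 2500 nM, with a likely range from 900 nM to 7000 nM.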

Compound 4, half-maximal inhibitory concentration: 3400 nM
Beside the measured number, compound 4's estimate is 1.4-fold (0.13 log units) below it, and the stated range covers the measured number.
By their numbers in this assay, from the lowest: compound 3; then compound 2; then compounds 1 and 4 (each within the scatter of the next).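

Going by these compounds alone, replacing cyclopropyl with (tert-butyl)amino on a carbonyl carbon whose other neighbour is an amide-type nitrogen in a ring gives the first single-place step: in this assay the step is a 1.2-fold higher number from compound 1 to compound 4 (0.08 log units; within the scatter) and so shows no measurable effect of this change. This position therefore accepts the loss of the three-membered ring and the arrival of a larger, open group carrying a hydrogen-bond donor, without a shift beyond the scatter in this read-out. No measurement at hand explains the result.

One replacement cannot show how far this tolerance extends. Still open, on these data alone, is whether a carboxylic acid, a primary amine or a longer chain such as n-hexyl on this carbonyl carbon would leave the number equally unmoved.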